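Methoxy on the Triazole Phenyl of a Diterpenoid Core

The source may hold more compounds than are shown below. What is called first, only, known or untested is meant among the compounds shown, and "the series" means these compounds.

Compound 1, `C=C1C(=O)[C@]23C[C@@]1(O)CC[C@H]2c1ccc(O)c(C)c1[C@@H]3Cn1cc(-c2ccccc2)nn1`: 260 nM
Compound 2, `C=C1C[C@]23C[C@@]1(O)CC[C@@H]2c1cccc(C)c1[C@@H]3Cn1cc(-c2ccc(Cl)cc2)nn1`: > 20000 nM
Compound 3, `Cc1ccc(-c2cn(C[C@H]3c4c(ccc(O)c4C)[C@@H]4CC[C@@]5(C)C[C@]43CC5=O)nn2)cc1`: > 20000 nM

Of the compounds shown here, three built on the shared core have been tested in a functional assay on SW480 cells (Homo sapiens) for cytotoxicity, read by MTT assay, with a stated time of 4 days; a higher number here means a weaker inhibitor, a lower number a stronger inhibitor. Compound 1 is the only one of them for which the assay returned a number, and in this assay compound 1 gives 260 nM. For compound 2 the assay reports only a limit, > 20000 nM. For compound 3 the assay likewise reports only a limit, > 20000 nM. Among the compounds with values here, because these two sit at the limit of > 20000 nM in this assay, at which 2 of the 3 values shown sit, no single step between measured compounds can be drawn, and compound 2 and compound 3 differ from compound 1 in more than one place, so their limits say only that neither reached a measurable value.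

Compound 4, `C=C1C(=O)[C@]23C[C@@]1(O)CC[C@H]2c1ccc(O)c(C)c1[C@@H]3Cn1cc(-c2ccc(OC)cc2)nn1`, has not yet been measured. It differs from compound 1 by methoxy in place of hydrogen on an aromatic carbon: the phenyl on the triazole becomes 4-methoxyphenyl, with the rest of the core unchanged. Within the data shown here, with no measured step to lean on, the change from compound 1 to compound 4 is expected to stay within the usual scatter of this assay, and a step of a 1.2-fold higher number from compound 1 to compound 4 (0.09 log units; within the scatter) is estimated, in no clear direction. Compound 4 is therefore expected to give about 320 nM, within a range from 100 nM to 1500 nM.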

Compound 4, half-maximal inhibitory concentration: 220 nM
Beside the measured number, compound 4's estimate is 1.5-fold (0.16 log units) above it; the measured number falls inside the stated range.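

Methoxy in place of hydrogen on an aromatic carbon, para to a large group, turns the phenyl on the triazole into 4-methoxyphenyl, and in this assay this gives a 1.2-fold lower number from compound 1 to compound 4 (0.07 log units; within the scatter). It is the only readable step among the compounds shown, and it shows that this position of the phenyl can carry methoxy with the shared core unchanged, while the result stays within the scatter and remains a measured number rather than a limit. Nothing measured here accounts for the size of this step, and no measured property of the group bears on it.

Going by these compounds, the steps to compound 2 and compound 3 cannot be read, since each of these two stands at a limit of the assay and differs from compound 1 in more than one place, so which of their differences matters remains open. Also open, on these data alone, is whether this position would accept an amine, a carboxylic acid or a longer chain such as butoxy as it accepts methoxy.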